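Swapping Trifluoromethoxy for Fluoro: What to Expect

A few compounds are considered here, and "the series" means these few. Any claim that something is new, unique, unknown or untested is made for them only; others in the source may bear on it.

Compound 1 `COc1cc(-n2ncnc2-c2ccc(OC(F)(F)F)cc2)cc(OC)c1OC`: > 10000 nM
Compound 2 `COc1cc(-c2ncnn2-c2ccc(Cl)cc2)cc(OC)c1OC`: > 10000 nM
Compound 3 `COc1cc(-c2ncnn2-c2cccc([N+](=O)[O-])c2)cc(OC)c1OC`: > 10000 nM

Of the compounds shown here, three have been tested in a functional assay on K562 cells (Homo sapiens) for antiproliferative activity, read by MTT assay, with a stated time of 72 h; a lower number here means a stronger inhibitor, a higher number a weaker inhibitor. For compound 1 the value > 10000 nM is a limit of the assay, not a number. For compound 2 the value > 10000 nM is likewise a limit. For compound 3 the value > 10000 nM is also a limit. Compound 1 therefore stands exactly where every measured compound stands, at the limit of > 10000 nM in this assay, at which 3 of the 3 values shown sit, and no numbers exist among them to rank one against another.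

Compound 4 `COc1cc(-n2ncnc2-c2ccc(F)cc2)cc(OC)c1OC` has not yet been measured. It differs from compound 1 in one place: fluoro in place of trifluoromethoxy on an aromatic carbon. Among the measured compounds shown here, no two measured compounds differ in a single place, and no measured step shows what such a change does.

For the measured compounds named here, the only guide is that compound 1 gives > 10000 nM in this assay, a limit. The step that the limit leaves unreadable from compound 1 to compound 4 is expected to be small, not beyond the scatter. For compound 4 the estimate is 20000 nM, with a range from 5000 nM to 100000 nM, and the assay is expected most likely to report again only a limit.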

Compound 4, half-maximal inhibitory concentration: > 10000 nM
Compound 4 was reported as a limit; the forecaster's own chance of this, stated with the estimate: 80%; the middle value does not contradict the limit.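

Compound 1 and compound 4 both stop at a limit of the assay, so the step from trifluoromethoxy to fluoro cannot be read, and all compounds shown sit at the same place: the limit of > 10000 nM in this assay, at which 4 of the 4 values shown sit. The compounds shown leave open how strongly any of them acts in this assay, and whether swapping these two groups changes that at all.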